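The source may hold more compounds than are shown below. What is called first, only, known or untested is meant among the compounds shown, and "the series" means these compounds.

Compound 1 `CC(=O)/C(C)=C/c1ccc([N+](=O)[O-])cc1` gives 70500 nM
Compound 2 `CC(=O)/C(C)=C/c1ccc(N(C)C)cc1` gives 160000 nM
Compound 3 `C/C(=C\c1ccccc1)C(=O)/C=C/c1ccccc1` gives 34500 nM

In an ADME assay on J774.A1 cells (Mus musculus) for cytotoxicity, read by MTT assay, with a stated time of 48 h (on this read-out higher numbers stand for lower toxicity in this test and lower numbers for higher toxicity in this test), compound 3 stands lowest of the three at 34500 nM and lies under compound 1 and further under compound 2. Compound 4 `C/C(=C\c1ccccc1)C(=O)/C=C/c1ccc([N+](=O)[O-])cc1` has nitro in place of hydrogen on an aromatic carbon. The change sits on an aromatic carbon of a six-membered aromatic ring of carbon only, para to a large group.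

For the measured compounds named here, only one measured step involves nitro. It swaps nitro for dimethylamino on an aromatic carbon and gives a 2.3-fold higher number from compound 1 to compound 2 (0.36 log units; beyond the scatter) in a modest move, so the nitro compound of that pair, compound 1, has the lower number. That pair has a different core and compares nitro with dimethylamino, not with hydrogen, which makes it a weak guide. Going by the values given here, no measured pair shows nitro replacing hydrogen directly.

On this evidence, a modest move to a lower number is expected, with real doubt about its size. The estimated change is a 1.4-fold lower number from compound 3 to compound 4 (0.16 log units; within the scatter) in this assay for this single replacement. The estimated value for compound 4 is 24000 nM with an expected range (9000 nM to 60000 nM) around it.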

Compound 4, half-maximal cytotoxic concentration: 26000 nM
Compound 4: middle estimate off by 1.1-fold (0.03 log units), on the low side; low and high end bracket the measured number.
By their numbers in this assay, from the lowest: compounds 4 and 3 (each within the scatter of the next); then compound 1; then compound 2.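

This pair gives the first direct view of nitro replacing hydrogen, on an aromatic carbon of a six-membered aromatic ring of carbon only, para to a large group. In this assay the replacement gives a 1.3-fold lower number from compound 3 to compound 4 (0.12 log units; within the scatter), so adding nitro at this position leaves the toxicity reading within the normal spread of repeat tests. Nothing in the available data offers an explanation for this result.

From the compounds shown here alone, it remains open whether dimethylamino at this same position on the shared core would raise the number, as it does on the different core in a 2.3-fold higher number from compound 1 to compound 2 (0.36 log units; beyond the scatter). Also open, going by these compounds, is how a carboxylic acid or a methoxy group at this position would compare with hydrogen and nitro.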